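A Smaller Aryl Group on the Shared Core

The source may report more compounds than this note shows. Statements on the series, on what has been measured and on what is new or still open speak of the compounds shown alone.

Measured so far:
Compound 1 `COc1cc2ncnc(Nc3ccc(C)cc3)c2cc1OCCCCC(=O)Nc1ccc(S(N)(=O)=O)cc1`: 19300 nM
Compound 2 `NS(=O)(=O)c1ccc(NC(=S)Nc2ccc3ncnc(Nc4ccc(Cl)c(C(F)(F)F)c4)c3c2)cc1`: 11800 nM

In a functional assay on NCI-H1975 cells (Homo sapiens) for antiproliferative activity, read by MTT assay, with a stated time of 72 h (a lower number here means a stronger inhibitor, a higher number a weaker inhibitor), compound 2 gives 11800 nM, and compound 1 gives 19300 nM; these two numbers lie within the usual scatter of each other, so neither stands apart. Compound 3 `Cc1ccc(Nc2ncnc3ccc(NC(=S)Nc4ccc(S(N)(=O)=O)cc4)cc23)cc1` is not yet measured. It differs from compound 2 in one place: 4-methylphenyl in place of 4-chloro-3-(trifluoromethyl)phenyl on a nitrogen on an aromatic ring. For the measured compounds named here, no measured pair shows this exact change, so its size is uncertain; the nearest guide is compound 1, which also carries 4-methylphenyl on the shared core and gives 19300 nM. A step of a 1.5-fold higher number from compound 2 to compound 3 (0.18 log units; within the scatter) is expected, barely beyond the scatter if at all. Compound 3 is estimated at 18000 nM, in the range 6000 nM to 50000 nM.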

Compound 3, half-maximal inhibitory concentration: 39400 nM
Compound 3: middle estimate off by 2.2-fold (0.34 log units), on the low side, within the range that was stated.
By their numbers in this assay, from the lowest: compounds 2 and 1 (each within the scatter of the next); then compound 3.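

Putting 4-methylphenyl in place of 4-chloro-3-(trifluoromethyl)phenyl on the nitrogen gives a 3.3-fold higher number from compound 2 to compound 3 (0.52 log units; beyond the scatter) in this assay. For the compounds shown here, this is the first one-place comparison here, and it shows that the group on this nitrogen affects the reading, though only modestly. No measurement shown explains the step.

As far as these compounds go, two things changed together, the chlorine and the trifluoromethyl group, so the share of each remains open. Also open, from the compounds shown here alone, is how a phenyl ring carrying an amine or a carboxylic acid would read on this nitrogen.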